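Working notes: aryl exchange on the shared core

The source may report more compounds than this note shows. Statements on the series, on what has been measured and on what is new or still open speak of the compounds shown alone.

Measured so far in a functional assay on MGC-803 cells (Homo sapiens) for inhibition, read by MTT assay, with a stated time of 72 h; a higher number here means a weaker inhibitor, a lower number a stronger inhibitor:
compound 1, `CC(C)c1ccc(-c2nc(SCc3cn(CC(=O)NC(=O)Nc4ccccn4)nn3)nc(Nc3cccc(C(F)(F)F)c3)c2C#N)cc1`: > 64000 nM, a limit of the assay rather than a number.
compound 2, `CC(C)c1ccc(-c2nc(SCc3cn(CC(=O)NC(=O)Nc4ccccn4)nn3)nc(Nc3ccccc3)c2C#N)cc1`: 15800 nM.
compound 3, `COc1ccc(Nc2nc(SCc3cn(CC(=O)NC(=O)Nc4ccccn4)nn3)nc(-c3ccc(C(C)C)cc3)c2C#N)cc1`: > 64000 nM, again a limit.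

Compound 1 stands at the upper limit of this assay, and it is not alone there: the limit of > 64000 nM in this assay, at which 2 of the 3 values shown sit. Only compound 2 returns a number. The readable steps both concern the aryl group on the nitrogen: an at least 4.0-fold lower number from compound 1 to compound 2 (0.60 log units; beyond the scatter), and an at least 4.0-fold higher number from compound 2 to compound 3 (0.60 log units; beyond the scatter). The direct comparison a step that the two limits leave unreadable from compound 1 to compound 3 cannot be sized, since both ends are limits.

Compound 4, `COc1cc(-c2nc(SCc3cn(CC(=O)NC(=O)Nc4ccccn4)nn3)nc(Nc3cccc(C(F)(F)F)c3)c2C#N)cc(OC)c1OC`, differs from compound 1 in one place: 3,4,5-trimethoxyphenyl in place of 4-isopropylphenyl on an aromatic carbon. Within the data shown here, none of the measured steps touches the 4-isopropylphenyl; all of them leave it in place and vary the other aryl group. Among the measured compounds shown here, the series therefore gives no measured step that bears on this change, and no direction beyond the scatter can be read from it. Compound 1 contributes only a limit as the starting point, so the step that the limit leaves unreadable from compound 1 to compound 4 is itself an expectation without a fixed anchor. Compound 4 is accordingly estimated at 70000 nM, within 20000 nM to 200000 nM, with a substantial chance that the assay again reports only a limit.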

Compound 4, half-maximal inhibitory concentration: 8210 nM
Beside the measured number, compound 4's estimate is 8.5-fold (0.93 log units) above it; the measured number lies below the stated range.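

In this assay, 3,4,5-trimethoxyphenyl in place of 4-isopropylphenyl, on the aromatic carbon next to the ring nitrogen and ortho to a cyano group, gives an at least 7.7-fold lower number from compound 1 to compound 4 (0.89 log units; beyond the scatter). Among these compounds, this is the first readable step at this position, and it shows that the aryl group here can also move a compound off the limit; until now, only a change to the aryl group on the nitrogen had given a readable value, in compound 2. The size of the new step remains a bound, since its starting point is a limit and not a number: the limit of > 64000 nM in this assay, at which 2 of the 4 values shown sit.

The compounds shown leave open whether this step needs all three methoxy groups or whether a single 4-methoxyphenyl or a 3,5-dimethoxyphenyl at this position would give a similar result, and how a 4-hydroxyphenyl or a phenyl carrying a carboxylic acid would read. They also leave open whether 3,4,5-trimethoxyphenyl would shift the value when the 3-(trifluoromethyl)phenyl on the nitrogen is replaced by the phenyl of compound 2 or the 4-methoxyphenyl of compound 3.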